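The source may report more compounds than this note shows. Statements on the series, on what has been measured and on what is new or still open speak of the compounds shown alone.

Working notes on the series. Among the measured compounds shown here, compound 3 `Cc1ccc(S(=O)(=O)c2cnc3cc(F)ccc3c2-c2ccc(F)cc2)cc1F` sits second highest of the three numbers so far in an ADME assay on microsomes from liver (Homo sapiens) for metabolic stability, tested at 2.5 uM; a higher number here means faster removal of the compound, a lower number slower removal: compound 3 gives 2.33 mL/min, with compound 2 `Cc1ccc(S(=O)(=O)c2cnc3cc(F)ccc3c2-c2cccc(Cl)c2)cc1C` nearest at 4.01 mL/min, a gap within the scatter, and compound 1 `O=S(=O)(c1ccc(F)c(F)c1)c1cnc2cc(F)ccc2c1-c1cccc(Cl)c1` furthest at 0.38 mL/min, a gap beyond the scatter. For the measured compounds named here, the only measured step that differs in one place is an 11-fold higher number from compound 1 to compound 2 (1.02 log units; beyond the scatter), which concerns the group on the sulfonyl sulfur, not the aryl on the core.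

Compound 4 `Cc1ccc(S(=O)(=O)c2cnc3cc(F)ccc3c2-c2cccc(Cl)c2)cc1F` differs from compound 3 at the aromatic carbon of the core: 3-chlorophenyl in place of 4-fluorophenyl on an aromatic carbon. Going by the values given here, no measured step isolates this change; compound 1 and compound 2 both carry the 3-chlorophenyl, but each also differs from compound 3 at the sulfonyl sulfur, so their values speak to a mixed comparison only. With nothing shown for this change on its own, no step beyond the scatter is expected in this assay, and the number for compound 4 is expected near that of compound 3, a step of a 1.1-fold higher number from compound 3 to compound 4 (0.03 log units; within the scatter). The estimate for compound 4 in this assay is 2.5 mL/min, with a range from 1.1 mL/min to 5.5 mL/min.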

Compound 4, intrinsic clearance in a liver preparation (reported as CLH), per the amount of preparation that the assay uses: 2.13 mL/min
Estimate against measurement, compound 4: 1.2-fold (0.07 log units) above; the range from low to high includes it.
By their numbers in this assay, from the lowest: compound 1; then compounds 4, 3 and 2 (each within the scatter of the next).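

In this assay, among the compounds shown here, 3-chlorophenyl in place of 4-fluorophenyl on the aromatic carbon opposite the ring nitrogen gives a 1.1-fold lower number from compound 3 to compound 4 (0.04 log units; within the scatter), the first reading of this change on its own, with the group on the sulfonyl sulfur held constant. With the 3-chlorophenyl held constant, the aryl on the sulfur gives two further single-place steps: fluoro in place of methyl gives a 1.9-fold lower number from compound 2 to compound 4 (0.27 log units; within the scatter), whereas methyl in place of fluoro gives a 5.6-fold higher number from compound 1 to compound 4 (0.75 log units; beyond the scatter), so only the second lies beyond the scatter. No measurement at hand accounts for these steps.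

The compounds shown leave open whether the core aryl change reads the same with 3,4-difluorophenyl or 3,4-dimethylphenyl on the sulfonyl sulfur. They also leave open how an amine or a carboxylic acid on that aryl would read in this assay.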